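Aryl variation on the shared core: compound 3 to compound 4

The compounds below may be only part of what the source reports. "The series", "measured", "known", "first", "only" and "open" are said of these compounds alone.

Compound 1 `CCc1nnc([S+]([O-])Cc2ncc(C)c(OC)c2C)o1` gives 10000 nM in a functional assay on HUVEC cells (Homo sapiens) for inhibition, read by ELISA; a higher number here means a weaker inhibitor, a lower number a stronger inhibitor. Compound 2 `COc1c(C)cnc(C[S+]([O-])c2nnc(-c3ccccc3)o2)c1C` gives 6000 nM in this assay, and compound 3 `COc1c(C)cnc(C[S+]([O-])c2nnc(-c3ccc(F)cc3)o2)c1C` gives 11000 nM. Compound 3 holds the highest of the three numbers, with a 1.1-fold higher number from compound 1 to compound 3 (0.04 log units; within the scatter) and a 1.8-fold higher number from compound 2 to compound 3 (0.26 log units; within the scatter), so the three compounds cannot be ordered.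

Compound 4 `COc1c(C)cnc(C[S+]([O-])c2nnc(-c3ccccc3O)o2)c1C` differs from compound 3 by 2-hydroxyphenyl in place of 4-fluorophenyl on an aromatic carbon. For the measured compounds named here, the steps that bear on this change are the earlier swaps of the group on that carbon: a 1.7-fold lower number from compound 1 to compound 2 (0.22 log units; within the scatter), a 1.1-fold higher number from compound 1 to compound 3 (0.04 log units; within the scatter) and a 1.8-fold higher number from compound 2 to compound 3 (0.26 log units; within the scatter). None of them moved this assay beyond the scatter, so for compound 4 no step beyond the scatter is expected in either direction. For compound 4 the estimated value in this assay is 10000 nM, with an expected range of 4000 nM to 25000 nM. This corresponds to an expected step of a 1.1-fold lower number from compound 3 to compound 4 (0.04 log units; within the scatter).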

Compound 4, half-maximal inhibitory concentration: 8000 nM
The estimate for compound 4 lay 1.3-fold (0.10 log units) above the measured number, and the stated range covers the measured number.
By their numbers in this assay, from the lowest: compounds 2, 4, 1 and 3 (each within the scatter of the next).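

In this assay, the entering 2-hydroxyphenyl brings a hydrogen-bond donor and acceptor that 4-fluorophenyl lacks, yet the readings stay within the scatter: a 1.4-fold lower number from compound 3 to compound 4 (0.14 log units; within the scatter), a 1.3-fold higher number from compound 2 to compound 4 (0.12 log units; within the scatter) and a 1.3-fold lower number from compound 1 to compound 4 (0.10 log units; within the scatter). At this aromatic carbon, therefore, neither hydroxy nor fluoro on the phenyl gives a step beyond the scatter among the compounds shown. No other data bear on this result.

As far as these compounds go, whether an amine or carboxylic acid on the phenyl, or a longer chain in place of ethyl, would move this assay beyond the scatter remains open.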